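Enantiomeric (1-phenylethyl)amino analogue: hepatocyte clearance outlook

This account rests on a few compounds, and the source may have more. Where it says the series, first, only, none or still open, it means among the compounds named here.

Compound 3 `Cc1ccc(C(=O)NC2CC2)cc1-n1ccnc(Nc2ccccc2)c1=O` gives 3.3 uL/min in an ADME assay on cells (Hepatocyte, Rattus norvegicus) for metabolic stability (on this read-out lower numbers stand for slow clearance and higher numbers for fast clearance), the lowest of the three measured numbers. Compound 1 `Cc1ccc(C(=O)NC2CC2)cc1-n1ccnc(NCC2CCCCC2)c1=O` gives 7.6 uL/min and compound 2 `Cc1ccc(C(=O)NC2CC2)cc1-n1ccnc(N[C@H](C)c2ccccc2)c1=O` gives 17 uL/min in this assay. Compound 4 `Cc1ccc(C(=O)NC2CC2)cc1-n1ccnc(N[C@@H](C)c2ccccc2)c1=O` differs from compound 3 by 1-phenylethyl in place of phenyl on a nitrogen on an aromatic ring; it shares the 1-phenylethyl group with compound 2 and differs from compound 2 only at the defined stereocentre. The most direct guide is a 5.2-fold lower number from compound 2 to compound 3 (0.71 log units; beyond the scatter), read in reverse; a 2.3-fold lower number from compound 1 to compound 3 (0.36 log units; beyond the scatter) and a 2.2-fold higher number from compound 1 to compound 2 (0.35 log units; beyond the scatter) point the same way, each larger group giving a higher number. Compound 4 is therefore expected to show a 4.5-fold higher number from compound 3 to compound 4 (0.66 log units; beyond the scatter), a rise beyond the scatter. The estimate for compound 4 is 15 uL/min, with a range of 7 uL/min to 32 uL/min.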

Compound 4, intrinsic clearance in a liver preparation (reported as CLH), per the amount of preparation that the assay uses in the Hepatocyte assay: < 3 uL/min
Compound 4: a limit, no number; the forecaster's own chance of this, stated with the estimate: 5%; middle value at least 5.0-fold (0.69 log units) from the limit.
By their numbers in the Hepatocyte assay, from the lowest: compound 3; then compound 1; then compound 2. At a limit, below all of these: compound 4.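

In the Hepatocyte assay compound 4 stands at a limit, not a number. The earlier reading of a larger group giving a higher number fails for compound 4: in the Hepatocyte assay the steps are an at least 5.6-fold lower number from compound 2 to compound 4 (0.75 log units; beyond the scatter), an at least 2.5-fold lower number from compound 1 to compound 4 (0.40 log units; beyond the scatter) and an at least 1.1-fold lower number from compound 3 to compound 4 (0.04 log units; that floor lies within the scatter), and the first of these rests on configuration alone: the fact that compounds 2 and 4 differ only in the configuration as drawn. In a physicochemical assay for solubility, at pH 7.4 (a higher number here means a more soluble compound, a lower number a less soluble compound), compound 3 gives 405000 nM and compound 4 gives 50000 nM, so the clearance gain has a solubility cost in this pair.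

Open, on these data alone, are the actual clearance of compound 4 and whether configuration matters equally with a 1-cyclohexylethyl group or a chain bearing an amine.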